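Replacing acetyl with 3-bromophenyl in compound 3

The compounds below may be only part of what the source reports. "The series", "measured", "known", "first", "only" and "open" are said of these compounds alone.

Measured so far in an ADME assay on Vero 76 cells (Chlorocebus sabaeus) for cytotoxicity, read by crystal violet staining, with a stated time of 96 h (on this read-out lower numbers stand for higher toxicity in this test and higher numbers for lower toxicity in this test), are these values
- Compound 1 `FC(F)(F)c1cccc(NC(=S)Nc2ccc(Cl)cc2)c1` gives 11000 nM
- Compound 2 `FC(F)(F)c1cccc(NC(=S)Nc2ccccc2)c1` gives 39000 nM
- Compound 3 `CC(=O)NC(=S)Nc1cccc(C(F)(F)F)c1` gives > 100000 nM as a limit and not a number

Compound 3 stands at the limit of > 100000 nM in this assay, at which 1 of the 3 values shown sits, and therefore has no exact value. The change to compound 4 `FC(F)(F)c1cccc(NC(=S)Nc2cccc(Br)c2)c1` puts 3-bromophenyl in place of acetyl on an amide-type nitrogen. Going by the values given here, two measured steps bear on it when read in reverse: acetyl in place of phenyl (an at least 2.5-fold higher number from compound 2 to compound 3 (0.40 log units; beyond the scatter)) and acetyl in place of 4-chlorophenyl (an at least 9.0-fold higher number from compound 1 to compound 3 (0.95 log units; beyond the scatter)). Both are at least modest and beyond the scatter. Among the compounds with values here, a third step, hydrogen in place of chloro (a 3.5-fold higher number from compound 1 to compound 2 (0.55 log units; beyond the scatter)), is modest, and no bromo compound has yet been measured. A step of at least modest size toward a lower number, meaning higher toxicity in this test, is therefore expected (an at least 7.6-fold lower number from compound 3 to compound 4 (0.88 log units; beyond the scatter)). Compound 4 is estimated at about 13000 nM within an expected range (5000 nM to 35000 nM).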

Compound 4, half-maximal cytotoxic concentration: 14000 nM
The estimate for compound 4 lay 1.1-fold (0.03 log units) below the measured number; the measured number falls inside the stated range.
By their numbers in this assay, from the lowest: compounds 1 and 4 (each within the scatter of the next); then compound 2. At a limit, above all of these: compound 3.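

In this assay, as far as these compounds go, a halogen-bearing phenyl group on the amide-type nitrogen in place of acetyl gives an at least 7.1-fold lower number from compound 3 to compound 4 (0.85 log units; beyond the scatter), and the true size of this step stays open because compound 3 has only a limit and not a number: the limit of > 100000 nM in this assay, at which 1 of the 4 values shown sits. Bromo in place of hydrogen on the phenyl group also counts by itself, with a 2.8-fold lower number from compound 2 to compound 4 (0.44 log units; beyond the scatter). Exchanging 4-chlorophenyl for 3-bromophenyl gives a 1.3-fold higher number from compound 1 to compound 4 (0.10 log units; within the scatter), so these two groups cannot be told apart here.

Compound 1 and compound 4 differ in both the halogen and its place on the phenyl group, and the two changes cannot be separated. Also open, from the compounds shown here alone, is how a phenyl group carrying an amine or a carboxylic acid, or a longer chain in place of acetyl, would read in this assay.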